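Iodo in place of trifluoromethyl on compound 2

The compounds below may be only part of what the source reports. "The series", "measured", "known", "first", "only" and "open" are said of these compounds alone.

In a functional assay on NCI-H226 cells (Homo sapiens) for antiproliferative activity, read by MTT assay, with a stated time of 48 h (a higher number here means a weaker inhibitor, a lower number a stronger inhibitor), compound 1 (`Cc1cc(F)cc(Nc2cc(NC(=O)Nc3c(Cl)cccc3Cl)ncn2)c1`) gives 2960 nM, compound 2 (`COc1cc(NC(=O)Nc2cc(Nc3cc(C(F)(F)F)ccc3OC)ncn2)cc(OC)c1`) gives 14600 nM and compound 3 (`COc1cc(Nc2cc(NC(=O)Nc3c(Cl)cccc3Cl)ncn2)cc(OC)c1`) gives 16900 nM. Compound 2 stands level with compound 3 within the scatter, while compound 1 carries a lower number, beyond the scatter from compound 2.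

The next compound to be read is compound 4 (`COc1cc(NC(=O)Nc2cc(Nc3cc(I)ccc3OC)ncn2)cc(OC)c1`). It is compound 2 with iodo in place of trifluoromethyl on an aromatic carbon, meta to a large group and para to a methoxy group: iodo in place of trifluoromethyl on an aromatic carbon.

Among the measured compounds shown here, no two measured compounds differ in one place only, so the series gives no direct guide to this change. With no such guide, no step beyond the scatter is expected in this assay, and the reading of compound 2 at 14600 nM serves as the anchor. The expected step is a 1.2-fold lower number from compound 2 to compound 4 (0.09 log units; within the scatter). For compound 4 the estimate is 12000 nM, with an expected range of 4500 nM to 30000 nM.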

Compound 4, half-maximal inhibitory concentration: 19400 nM
For compound 4 the middle estimate is 1.6-fold (0.21 log units) below the measured one; the measured number falls inside the stated range.
By their numbers in this assay, from the lowest: compound 1; then compounds 2, 3 and 4 (each within the scatter of the next).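

In this assay, iodo in place of trifluoromethyl on the aromatic carbon para to a methoxy group gives a 1.3-fold higher number from compound 2 to compound 4 (0.12 log units; within the scatter). Among the compounds shown here, this is the first one-place comparison, and it shows that this exchange at this position leaves the reading level, even though the entering group has fewer heavy atoms than the one leaving. No measurement beyond these readings bears on the result.

Still open, on these data alone, is whether an amine, a carboxylic acid or a longer alkyl chain on this same carbon would also stay within the scatter of compound 2, since only trifluoromethyl and iodo are compared here. Also open, as far as these compounds go, is whether iodo in place of trifluoromethyl would read the same way on the core of compound 1.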